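From Ethynyl to Phenyl on a Shared Core

This account rests on a few compounds, and the source may have more. Where it says the series, first, only, none or still open, it means among the compounds named here.

Compound 1 `CC(C)C1=C(C(=O)OCC2CCCCC2)C(c2cccc(O)c2)NC(=O)N1` has no usable result in an ADME assay on CEMx174 cells (Homo sapiens) for cytotoxicity (on this read-out lower numbers stand for higher toxicity in this test and higher numbers for lower toxicity in this test), and is recorded as "not determined" (no result reported) there, so it offers no number to compare. In this assay compound 2 `C#CC1=C(C(=O)OCC2CCCCC2)C(c2cccc(O)c2)NC(=O)N1` reads > 1000 nM as a limit of the assay, not as a number. Compound 3 `O=C1NC(c2ccccc2)=C(C(=O)OCC2CCCCC2)C(c2cccc(O)c2)N1` has not been measured yet. Going by the values given here, it carries phenyl in place of ethynyl on a double-bonded ring carbon, and the counted change phenyl in place of ethynyl on a double-bonded ring carbon is the only difference from compound 2. Among the compounds with values here, no measured step shows what such a swap does in this assay here, so the expectation rests on compound 2 alone, at > 1000 nM as a limit. The step that the limit leaves unreadable from compound 2 to compound 3 is expected to be modest and to point toward higher numbers, meaning lower toxicity in this test, though this estimate is loose. this assay may again report only a limit for compound 3. For compound 3 the expected value is 8000 nM within an estimated range from 1500 nM to 50000 nM in this estimate.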

Compound 3, half-maximal cytotoxic concentration: > 10000 nM
Compound 3: no number, only a limit (the forecaster's own chance of this, stated with the estimate: 50%); middle value at least 1.2-fold (0.09 log units) from the limit.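

In this assay, going by these compounds alone, compound 2 and compound 3 each give only a limit of the assay rather than a number, so no step between these two compounds can be read. From the compounds shown here alone, the true half-maximal cytotoxic concentration of each compound stays open, and so does the effect of phenyl in place of ethynyl on a double-bonded ring carbon.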